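Vinyl for Cyclopropyl: A Step Beyond the Assay Limit

The source may hold more compounds than are shown below. What is called first, only, known or untested is meant among the compounds shown, and "the series" means these compounds.

Compound 1 `COc1ccn2ncc(/C=N/N(C)S(=O)(=O)c3cc([N+](=O)[O-])ccc3C)c2c1`: > 1000 nM
Compound 2 `Cc1ccc([N+](=O)[O-])cc1S(=O)(=O)N(C)/N=C/c1cnn2ccc(C3CC3)cc12`: > 1000 nM

In an assay on isolated protein for inhibition of phosphatidylinositol 4,5-bisphosphate 3-kinase catalytic subunit beta isoform (Homo sapiens), read by 33P incorporation, with a stated time of 60 min (on this read-out higher numbers stand for weaker inhibition and lower numbers for stronger inhibition), compound 1 gives only a limit, > 1000 nM. Compound 2 also gives only a limit in this assay, > 1000 nM. Among the compounds with values here, the single measured step, a step that the two limits leave unreadable from compound 1 to compound 2, has no readable size because of the limit of > 1000 nM in this assay, at which 2 of the 2 values shown sit. Compound 3 `C=Cc1ccn2ncc(/C=N/N(C)S(=O)(=O)c3cc([N+](=O)[O-])ccc3C)c2c1` differs from compound 2 by vinyl in place of cyclopropyl on an aromatic carbon. Within the data shown here, no measured step bears on this change with a number, so no direction beyond the scatter can be expected. Compound 3 is therefore estimated at 3000 nM, within 800 nM to 20000 nM. The expected step is a step that the limit leaves unreadable from compound 2 to compound 3.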

Compound 3, half-maximal inhibitory concentration: > 1000 nM
Compound 3: a limit, no number; the forecaster's own chance of this, stated with the estimate: 80%; the middle value lies beyond the limit too.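

No new step can be read among compound 1, compound 2 and compound 3, because all of them stop at one limit: the limit of > 1000 nM in this assay, at which 3 of the 3 values shown sit. Going by these compounds, how strongly each inhibits, and whether methoxy, cyclopropyl and vinyl differ at all, stays open.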